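One Aryl Group Exchanged: From Compound 1 to Compound 4

A few compounds are considered here, and "the series" means these few. Any claim that something is new, unique, unknown or untested is made for them only; others in the source may bear on it.

Compound 1 `COc1cc(/C=C/C(=O)c2cccc(-n3cc(-c4ccc(Cl)cc4)[nH]c3=O)c2)cc(OC)c1OC` was tested in a functional assay on SNB-75 cells (Homo sapiens) for inhibition (on this read-out lower numbers stand for stronger inhibition of growth and higher numbers for weaker inhibition of growth), and came back as "not active" (no number reported), so no single number marks where it stands. Two related compounds do give numbers in this assay: compound 2 `COc1cc(/C=C/C(=O)c2cccc(-n3cc(-c4ccccc4)[nH]c3=O)c2)ccc1O` gives 3900 nM, and compound 3 `O=C(/C=C/c1cccc(O)c1)c1cccc(-n2cc(-c3ccc(Cl)cc3)[nH]c2=O)c1` gives 1460 nM. Compound 4 `COc1cc(/C=C/C(=O)c2cccc(-n3cc(-c4cc(OC)c(OC)c(OC)c4)[nH]c3=O)c2)cc(OC)c1OC` has not yet been measured. It differs from compound 1 in one place: 3,4,5-trimethoxyphenyl in place of 4-chlorophenyl on an aromatic carbon. Going by the values given here, no step between measured compounds tracks this exchange, so its size and direction cannot be read from the data, and neither compound 2 nor compound 3 carries a 3,4,5-trimethoxyphenyl on the shared core. Among the compounds with values here, the only anchor is that compound 1 was reported as "not active" (no number reported) in this assay. Compound 4 is on that basis expected to stay weak, with an estimated value of 15000 nM and a range from 3000 nM to 80000 nM, and with a real chance that this assay again reports no number for it.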

Compound 4, concentration for 50% growth inhibition: 5130 nM
Beside the measured number, compound 4's estimate is 2.9-fold (0.47 log units) above it; the range from low to high includes it.
By their numbers in this assay, from the lowest: compound 3; then compounds 2 and 4 (each within the scatter of the next).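

In this assay compound 4 gives 5130 nM while compound 1 gives "not active" (no number reported) and thus no new step can be read between them. The compounds shown leave open how large the exchange of 4-chlorophenyl for 3,4,5-trimethoxyphenyl is. No measurement here offers an explanation for the result.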